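Replacing the benzyloxycarbonyl group on compound 3

The source may report more compounds than this note shows. Statements on the series, on what has been measured and on what is new or still open speak of the compounds shown alone.

In a functional assay on A549 cells (Homo sapiens) for cytotoxicity, read by colorimetric assay and MTT assay (on this read-out lower numbers stand for stronger inhibition and higher numbers for weaker inhibition), compound 1 (`COc1cccc2cc(-c3ccccc3)c(O)nc12`) gives 10000 nM, and compound 2 (`COc1ccc2cc(-c3ccccc3)c(O)nc2c1`) gives 10000 nM. Compound 3 (`COc1ccc(-c2cc3c(OC)cc(OC)cc3n(CC(=O)OCc3ccccc3)c2=O)cc1`) gives 10000 nM, level with both, so the three measured compounds show no spread. Compound 4 (`CCN(CC)C(=O)CCn1c(=O)c(-c2ccc(OC)cc2)cc2c(OC)cc(OC)cc21`) departs from compound 3 at one place: (diethylcarbamoyl)methyl in place of benzyloxycarbonyl on a saturated chain carbon bound to an aromatic nitrogen. Among the compounds with values here, no measured pair shows a change of this kind, so the expectation rests only on the three level values, including compound 3 at 10000 nM. In this assay the expected change, a 1.1-fold lower number from compound 3 to compound 4 (0.05 log units; within the scatter), is none beyond the scatter, with no direction favoured. Compound 4 is estimated at 9000 nM, with an expected range of 2500 nM to 20000 nM.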

Compound 4, half-maximal inhibitory concentration: 10000 nM
Estimate against measurement, compound 4: 1.1-fold (0.05 log units) below; low and high end bracket the measured number.
By their numbers in this assay, from the lowest: compounds 1, 2, 3 and 4 (each within the scatter of the next).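

In this assay, (diethylcarbamoyl)methyl in place of benzyloxycarbonyl on a saturated chain carbon bound to an aromatic nitrogen shows no change at the digits printed from compound 3 to compound 4 (within the scatter). Within the data shown here, this is the first one-place comparison: at this place, losing the six-membered aromatic ring and gaining an amide nitrogen leaves the read-out level. No supporting measurement bears on this result.

Going by these compounds, whether any group at this place can move the number remains open. A carboxylic acid or a primary amine at the end of the chain would test this, as would a longer chain.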